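This account rests on a few compounds, and the source may have more. Where it says the series, first, only, none or still open, it means among the compounds named here.

In a functional assay on thoracic aorta (Rattus norvegicus, strain Wistar), with a stated time of 15 min (on this read-out higher numbers stand for an effect only at larger amounts of compound and lower numbers for an effect already at smaller amounts), compound 1 (`CCOc1ccc(Br)cc1C(C)NC(=O)N(C)S(=O)(=O)c1ccc(Cl)cc1`) gives 55700 nM, and compound 2 (`CC(NC(=O)N(C)S(=O)(=O)c1ccc(Cl)cc1)c1cc(Br)ccc1OCc1ccccc1`) gives 146000 nM, the higher of the two numbers. Compound 3 (`CC(NC(=O)N(C)S(=O)(=O)c1ccc(Cl)cc1)c1ccccc1OCc1ccccc1`) carries hydrogen in place of bromo on an aromatic carbon of compound 2: hydrogen in place of bromo on an aromatic carbon. For the measured compounds named here, the only measured step, a 2.6-fold higher number from compound 1 to compound 2 (0.42 log units; beyond the scatter), is modest and lies at another place, so no measured step shows what removing the bromo does. No step beyond the scatter is therefore expected in this assay, and no direction is favoured. The expected step is a 1.1-fold lower number from compound 2 to compound 3 (0.05 log units; within the scatter). For compound 3 the estimated value is 130000 nM, with an expected range from 45000 nM to 380000 nM.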

Compound 3, half-maximal effective concentration: 38400 nM
Estimate against measurement, compound 3: 3.4-fold (0.53 log units) above; measured number below the stated range.
By their numbers in this assay, from the lowest: compounds 3 and 1 (each within the scatter of the next); then compound 2.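

Removing the bromo from the aromatic carbon para to a benzyloxy group gives a 3.8-fold lower number from compound 2 to compound 3 (0.58 log units; beyond the scatter) in this assay. For the compounds shown here, this is the first measured change at this position, and it shows that the position is not silent: with the benzyloxy group in place, hydrogen goes with an effect at smaller amounts than bromo. Nothing available explains this step. Going by these compounds, whether the same change would act alike with the ethoxy group of compound 1 stays open. So does what chloro, methoxy or an amine would give at this aromatic carbon.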